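Triazole N-aryl swap in a biphenyl diol series

The source may report more compounds than this note shows. Statements on the series, on what has been measured and on what is new or still open speak of the compounds shown alone.

Going by the values given here, compound 2 `O[C@H](COCCOC[C@@H](O)Cc1cn(-c2ccc3c(c2)OCCO3)nn1)Cc1ccc(-c2ccccc2)cc1` carries the only real number in a functional assay on SGC-7901 cells (Homo sapiens) for inhibition, read by MTT assay, with a stated time of 72 h; a lower number here means a stronger inhibitor of growth, a higher number a weaker inhibitor of growth: compound 2 gives 6400 nM. The parent with hydrogen on the triazole nitrogen, compound 1 `O[C@H](COCCOC[C@@H](O)Cc1c[nH]nn1)Cc1ccc(-c2ccccc2)cc1`, reports only a limit, > 100000 nM (the limit of > 100000 nM in this assay, at which 1 of the 2 values shown sits). Among the compounds with values here, the single measured step, an at least 15-fold lower number from compound 1 to compound 2 (1.19 log units; beyond the scatter), is thus known only as a bound on its size.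

Compound 3 `O[C@H](COCCOC[C@@H](O)Cc1cn(-c2ccc3[nH]ccc3c2)nn1)Cc1ccc(-c2ccccc2)cc1` differs from compound 2 by 1H-indol-5-yl in place of 2,3-dihydro-1,4-benzodioxin-6-yl on an aromatic nitrogen. Within the data shown here, no measured step exchanges one aryl group for another on that nitrogen; the only step bearing on the site is an at least 15-fold lower number from compound 1 to compound 2 (1.19 log units; beyond the scatter), which shows an aryl group there is worth a large gain over hydrogen. Whether indolyl and benzodioxinyl differ is not shown, so no step beyond the scatter is expected in this assay; the expected step is a 1.1-fold lower number from compound 2 to compound 3 (0.03 log units; within the scatter). Compound 3 is estimated at 6000 nM, within 2000 nM to 20000 nM.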

Compound 3, concentration for 50% growth inhibition: 45600 nM
The estimate for compound 3 lay 7.6-fold (0.88 log units) below the measured number, outside the stated range (above it).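

In this assay, the choice of aryl group on this aromatic nitrogen matters, not only its presence: replacing 2,3-dihydro-1,4-benzodioxin-6-yl gives a 7.1-fold higher number from compound 2 to compound 3 (0.85 log units; beyond the scatter). The gain over hydrogen therefore depends on which aryl group is present, and 1H-indol-5-yl retains a smaller gain, with an at least 2.1-fold lower number from compound 1 to compound 3 (0.34 log units; beyond the scatter). The size of that gain is only a bound, as compound 1 is recorded at a limit: the limit of > 100000 nM in this assay, at which 1 of the 3 values shown sits.

The compounds shown do not separate the hydrogen-bond donor entering with 1H-indol-5-yl from the hydrogen-bond acceptors leaving with 2,3-dihydro-1,4-benzodioxin-6-yl, or either from the change in ring type. A plain phenyl group or a 1-methyl-1H-indol-5-yl group on that nitrogen would bear on this question.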